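Compound 3: 3-methoxyphenyl in place of 4-methoxyphenyl

A few compounds are considered here, and "the series" means these few. Any claim that something is new, unique, unknown or untested is made for them only; others in the source may bear on it.

In a functional assay on A549 cells (Homo sapiens) for inhibition, read by MTT assay, with a stated time of 72 h (on this read-out lower numbers stand for stronger inhibition and higher numbers for weaker inhibition), compound 1 `CC(C)c1ccc(NC(=O)C2CCN(C/C=C/c3ccccc3)CC2)cc1` gives 9430 nM and compound 2 `COc1ccc(NC(=O)C2CCN(C/C=C/c3ccccc3)CC2)cc1` gives 83800 nM, so compound 2 holds the higher of the two numbers and the weaker inhibition. Among the compounds with values here, only one measured step bears on what follows: an 8.9-fold higher number from compound 1 to compound 2 (0.95 log units; beyond the scatter), with methoxy in place of isopropyl on an aromatic carbon. Compound 3 `COc1cccc(NC(=O)C2CCN(C/C=C/c3ccccc3)CC2)c1` has the same atoms as compound 2, joined differently, with 3-methoxyphenyl in place of 4-methoxyphenyl on an amide-type nitrogen. The measured step exchanges one group for another, whereas here methoxy remains, so it offers only an indirect guide. Within the data shown here, no measured pair shows what this kind of change does. Among the measured compounds shown here, a step smaller than the modest one already seen is therefore expected, possibly none beyond the scatter, with a slight lean toward a lower number as compound 2 is the higher of only two values. The estimated change is a 1.5-fold lower number from compound 2 to compound 3 (0.18 log units; within the scatter). In this assay, the estimate for compound 3 is 55000 nM, with an expected range from 18000 nM to 160000 nM.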

Compound 3, half-maximal inhibitory concentration: 50500 nM
Compound 3: middle estimate off by 1.1-fold (0.04 log units), on the high side; measured number inside the range.
By their numbers in this assay, from the lowest: compound 1; then compounds 3 and 2 (each within the scatter of the next).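

In this assay, 3-methoxyphenyl in place of 4-methoxyphenyl on the amide-type nitrogen gives a 1.7-fold lower number from compound 2 to compound 3 (0.22 log units; within the scatter), so the two methoxy isomers cannot be told apart on this read-out, and the place of the methoxy on the aromatic ring carries no visible weight here. The isopropyl compound stays clearly apart from the new isomer, with a 5.4-fold higher number from compound 1 to compound 3 (0.73 log units; beyond the scatter), so the gap first seen with 4-methoxyphenyl persists with 3-methoxyphenyl, and compound 1, bearing 4-isopropylphenyl, remains the strongest inhibitor of the three. Nothing available gives a measured reason for either of these results.

The compounds shown leave open whether an isopropyl group would behave as the methoxy group does in the same exchange, as 3-isopropylphenyl in place of 4-isopropylphenyl would show. They also leave open how the numbers would run with other groups on the aromatic ring, such as an amine, a carboxylic acid or a longer alkyl chain, and so whether anything can reach beyond the level of compound 1.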